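A few compounds are considered here, and "the series" means these few. Any claim that something is new, unique, unknown or untested is made for them only; others in the source may bear on it.

Measured so far:
compound 1 `CCc1ccc(NS(=O)(=O)c2ccc(N3CCNC3=O)cc2)cc1` – 480 nM in a functional assay on M21 cells (Homo sapiens) for antiproliferative activity, read by sulforhodamine B assay, with a stated time of 48 h; a lower number here means a stronger inhibitor, a higher number a weaker inhibitor
compound 2 `CCCCCCOc1ccc(NS(=O)(=O)c2ccc(N3CCNC3=O)cc2)cc1` – a limit in this assay, > 1000 nM

Going by the values given here, compound 1 holds the only number in this assay; compound 2 sits at a limit. Against compound 2 the step of an at least 2.0-fold higher number from compound 1 to compound 2 (0.31 log units; beyond the scatter) is the sole measured change, and its size is bounded only by the limit of > 1000 nM in this assay, at which 1 of the 2 values shown sits. Compound 3 `Cc1ccccc1NS(=O)(=O)c1ccc(N2CCNC2=O)cc1` differs from compound 1 in one place: 2-methylphenyl in place of 4-ethylphenyl on a sulfonamide nitrogen. The measured step concerns a group on an aromatic carbon, whereas here the whole aryl group on the sulfonamide nitrogen is exchanged, so it bears on the new change only loosely; it shows merely that this assay registers changes on that aryl group at all. With a small shift in the carbon count and no change in donors or acceptors, a step of a 1.4-fold higher number from compound 1 to compound 3 (0.13 log units; within the scatter) is expected, near the scatter. Compound 3 is therefore estimated at 650 nM, in the range 250 nM to 1700 nM.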

Compound 3, half-maximal inhibitory concentration: 150 nM
Estimate against measurement, compound 3: 4.3-fold (0.64 log units) above; the measured number lies below the stated range.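

In this assay, 2-methylphenyl in place of 4-ethylphenyl on a sulfonamide nitrogen gives a 3.2-fold lower number from compound 1 to compound 3 (0.51 log units; beyond the scatter), so changes to this aryl group can strengthen inhibition as well as weaken it. The earlier pair showed a shift in the weaker direction only, whereas here the group with one carbon fewer gives the stronger compound of the pair. The exchange alters both the alkyl group and its place on the ring, so the gain can be assigned only to the exchange as a whole.

How far compound 2 lies from compound 1 cannot be read, as compound 2 stands at a limit: the limit of > 1000 nM in this assay, at which 1 of the 3 values shown sits. Still open, from the compounds shown here alone, are the separate contributions of the alkyl group and its ring place, and the effect of an amine or a carboxylic acid on this aryl group.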